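The source may hold more compounds than are shown below. What is called first, only, known or untested is meant among the compounds shown, and "the series" means these compounds.

Measured compounds:
compound 1 `O=C(COc1ccc(C(=O)/C=C/c2ccccc2Cl)cc1)N[C@H]1CCOC1=O` — 3240 nM
compound 2 `O=C(CNc1ccccc1)N[C@H]1CCOC1=O` — > 64000 nM
compound 3 `O=C(COc1ccc(C(=O)/C=C/c2ccccc2)cc1)N[C@H]1CCOC1=O` — 48300 nM

These compounds were tested in a functional assay on DU-145 cells (Homo sapiens) for antiproliferative activity, read by MTT assay, with a stated time of 72 h; on this read-out higher numbers stand for weaker inhibition and lower numbers for stronger inhibition. Compound 3 gives 48300 nM and compound 1 gives 3240 nM in this assay. Compound 2 reaches only the limit of this assay, (the limit of > 64000 nM in this assay, at which 1 of the 3 values shown sits), so its result is a limit and not a number. The step of a 15-fold lower number from compound 3 to compound 1 (1.17 log units; beyond the scatter) arises from a single change, (chloro in place of hydrogen on an aromatic carbon). The difference between the cores of compound 2 and compound 3 is not broken down here.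

Compound 4 `O=C(CNc1ccccc1Cl)N[C@H]1CCOC1=O` has not yet been measured. It differs from compound 2 by chloro in place of hydrogen on an aromatic carbon, the same change as that from compound 3 to compound 1. For compound 4 a step of an at least 1.0-fold lower number from compound 2 to compound 4 (0.02 log units; that floor lies within the scatter) is expected, resting on the earlier step of a 15-fold lower number from compound 3 to compound 1 (1.17 log units; beyond the scatter) and on the limit of compound 2. Compound 4 is therefore estimated at 60000 nM, with a range from 15000 nM to 250000 nM.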

Compound 4, half-maximal inhibitory concentration: > 64000 nM
Compound 4 gave a limit, no number; the forecaster's own chance of this, stated with the estimate: 60%; at least 1.0-fold (0.02 log units) between middle value and limit.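

Compound 2 and compound 4 both give only a limit, not a number, so no step between them can be read: the limit of > 64000 nM in this assay, at which 2 of the 4 values shown sit.

As far as these compounds go, whether chloro in place of hydrogen lowers the number on the core of compound 2, as it does on the core of compound 3, stays open.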